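A cyclopentylcarbonylamino group in place of benzyl

A few compounds are considered here, and "the series" means these few. Any claim that something is new, unique, unknown or untested is made for them only; others in the source may bear on it.

Measured so far:
compound 1, `CN(C)C(=O)/C=C/c1ccc2noc(-c3ccccc3)c2c1`, 40300 nM
compound 2, `O=C(O)/C=C/c1ccc2noc(-c3ccc(-c4ccccc4)cc3)c2c1`, 74 nM
compound 3, `O=C(O)c1ccc2noc(-c3ccc(Cc4ccccc4)cc3)c2c1`, 65 nM

These three compounds share a core and were tested in an assay for inhibition of inositol hexakisphosphate kinase 2 (Homo sapiens), read by colorimetric assay, coupled enzyme assay and malachite green, with a stated time of 120 min, in the presence of a further agent that is not named here; a lower number here means a stronger inhibitor, a higher number a weaker inhibitor. Compound 3 has the lowest number of the three. Its nearest neighbour is compound 2, whose value lies within the usual scatter of repeated measurements, so the two cannot be told apart. Compound 1 stands far above both, a gap well beyond the scatter.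

Compound 4, `O=C(O)c1ccc2noc(-c3ccc(NC(=O)C4CCCC4)cc3)c2c1`, has not yet been measured. It differs from compound 3 in one place: (cyclopentylcarbonyl)amino in place of benzyl on an aromatic carbon. The carboxylic acid and the core are kept. Among the compounds with values here, no measured pair in this set shows this kind of exchange, so the size of the step cannot be read from the data. Both substituents are large groups para to the core attachment, and the two most potent compounds, compound 2 and compound 3, both carry a large group there. A small step is therefore expected, with the direction uncertain; the estimated step of a 1.8-fold higher number from compound 3 to compound 4 (0.27 log units; within the scatter) is taken as a modest rise. Compound 4 is expected to give 120 nM in this assay, in a range from 30 nM to 500 nM.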

Compound 4, half-maximal inhibitory concentration: 190 nM
Compound 4: the middle estimate sits 1.6-fold (0.20 log units) below what was measured, and the stated range covers the measured number.
By their numbers in this assay, from the lowest: compounds 3 and 2 (each within the scatter of the next); then compound 4; then compound 1.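

In this assay, putting (cyclopentylcarbonyl)amino in place of benzyl on this aromatic carbon gives a 2.9-fold higher number from compound 3 to compound 4 (0.47 log units; beyond the scatter), so the two large groups are not interchangeable at this position. The change is still modest, even though the entering group has a hydrogen-bond donor, a hydrogen-bond acceptor and a five-membered non-aromatic ring, none of which benzyl has, so this position accepts groups of quite different make-up. No measurement at hand gives a reason for the rise.

The amide link and the cyclopentyl ring change together here, so which of them accounts for the step stays open. A benzoylamino group or a cyclopentylmethyl group in this place would separate the two, and a plain amino group would test whether a large group is needed there at all.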